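Hydroxy in Place of Fluoro: Compound 3 Expected

A few compounds are considered here, and "the series" means these few. Any claim that something is new, unique, unknown or untested is made for them only; others in the source may bear on it.

compound 1 `CN(C)CCn1cnnc1-c1cc(Oc2ccc(NC(=O)N/N=C/c3cc(C(C)(C)C)cc(C(C)(C)C)c3O)cc2F)ccn1` — 980 nM
compound 2 `CN(C)CCn1cnnc1-c1cc(Oc2ccc(NC(=O)N/N=C/c3ccc(F)cc3)cc2F)ccn1` — 1790 nM

In a functional assay on A549 cells (Homo sapiens) for cytotoxicity, read by MTT assay, with a stated time of 72 h (a higher number here means a weaker inhibitor, a lower number a stronger inhibitor), compound 2 gives 1790 nM, the highest of the two numbers measured, while compound 1 gives 980 nM, a gap that lies within the usual scatter, so no order between the two can be claimed. Compound 3 `CN(C)CCn1cnnc1-c1cc(Oc2ccc(NC(=O)N/N=C/c3ccc(O)cc3)cc2F)ccn1` differs from compound 2 in one place: hydroxy in place of fluoro on an aromatic carbon. For the measured compounds named here, no measured pair shows this change, so the expected step is small, within the scatter, in no clear direction: a 1.2-fold lower number from compound 2 to compound 3 (0.08 log units; within the scatter). Compound 3 is therefore estimated at 1500 nM in this assay, ranging from 500 nM to 4500 nM.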

Compound 3, half-maximal inhibitory concentration: 3560 nM
Beside the measured number, compound 3's estimate is 2.4-fold (0.38 log units) below it; low and high end bracket the measured number.
By their numbers in this assay, from the lowest: compounds 1, 2 and 3 (each within the scatter of the next, the first and the last beyond it).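

In this assay, this first pair at the position gives a step (a 2.0-fold higher number from compound 2 to compound 3 (0.30 log units; within the scatter)) that remains within the scatter, so 4-hydroxyphenyl and 4-fluorophenyl cannot be told apart here, even though the hydroxy adds a hydrogen-bond donor and a hydrogen-bond acceptor. One pair cannot show how this change behaves on other compounds, and nothing available explains the result. On these data alone, it remains open whether an amine, a methoxy group or a carboxylic acid on this aromatic carbon, para to the large group, would give a step beyond the scatter.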